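A few compounds are considered here, and "the series" means these few. Any claim that something is new, unique, unknown or untested is made for them only; others in the source may bear on it.

Measured so far:
Compound 1 `CCCc1cc(N2CCCC2)c2cc(NC(=O)/C=C/c3ccc(C(F)(F)F)cc3)ccc2n1`: 17 nM
Compound 2 `CCCc1cc(N)c2cc(NC(=O)/C=C/c3ccc(Cl)c(Cl)c3)ccc2n1`: 60 nM
Compound 3 `Nc1cc(C2CCCCC2)nc2ccc(NC(=O)/C=C/c3ccc(C(F)(F)F)cc3)cc12`: 1.2 nM

In an assay on isolated protein for displacement of a labelled ligand from melanin-concentrating hormone receptor 1 (Homo sapiens) (a higher number here means a weaker inhibitor, a lower number a stronger inhibitor), compound 1 gives 17 nM. Among the three numbers that is the second highest: compound 2 sits higher, beyond the scatter, and compound 3 lower, also beyond the scatter. No pair among these three differs in one place only, so no single-change step is known.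

Compound 4 `CCCc1cc(N2CCC2)c2cc(NC(=O)/C=C/c3ccc(C(F)(F)F)cc3)ccc2n1` is not yet measured. It differs from compound 1 by azetidin-1-yl in place of pyrrolidin-1-yl on an aromatic carbon. The rest of compound 1 stays as it is, and nothing in the measured set shows what exchanging one such ring for the other does in this assay. The step of a 1.5-fold higher number from compound 1 to compound 4 (0.17 log units; within the scatter) is expected to be small, around the scatter, with no firm direction. Compound 4 is expected to give 25 nM, with a range of 8 nM to 80 nM.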

Compound 4, half-maximal inhibitory concentration: 2.8 nM
Compound 4: the middle estimate sits 8.9-fold (0.95 log units) above what was measured, outside the stated range (below it).
By their numbers in this assay, from the lowest: compound 3; then compound 4; then compound 1; then compound 2.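

In this assay, the position opposite the ring nitrogen responds to ring size: azetidin-1-yl in place of pyrrolidin-1-yl gives a step beyond the scatter (a 6.1-fold lower number from compound 1 to compound 4 (0.78 log units; beyond the scatter)). The two groups differ in ring size and heavy-atom count, but not in counted hydrogen-bond donors, acceptors or net charge. Nothing available explains the step.

Still open, going by these compounds, is how a piperidine ring or an open-chain dimethylamino group would read at this position. It is also unclear whether the step holds with a cyclohexyl group in place of the propyl group.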